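This account rests on a few compounds, and the source may have more. Where it says the series, first, only, none or still open, it means among the compounds named here.

In a physicochemical assay for lipophilicity (a higher number here means a more lipophilic compound, a lower number a more polar compound), compound 1 (`CC(C)c1cc(I)cc(C(C)C)c1O`) gives 5.75 and compound 2 (`CC(C)c1cc(C(=O)c2ccccc2)cc(C(C)C)c1O`) gives 5.91 so the two stand within the scatter of each other. Compound 3 (`CC(C)c1cc(N(C)C)cc(C(C)C)c1O`) is not yet measured and differs from compound 1 thus: dimethylamino in place of iodo on an aromatic carbon with dimethylamino in place of iodo on an aromatic carbon, para to a hydroxy group. Among the compounds with values here, no step between measured compounds covers this change, so the expectation rests on the structural change alone. The expected move is downward and beyond the scatter, with an estimated step (a number 0.95 log units lower from compound 1 to compound 3 (beyond the scatter)). Compound 3 is expected at 4.8 with 4.2 and 5.3 as the ends of the estimated range.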

Compound 3, partition coefficient: 4.52
For compound 3 the middle estimate is 0.28 log units above the measured one; measured number inside the range.
By their numbers in this assay, from the lowest: compound 3; then compounds 1 and 2 (each within the scatter of the next).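

In this assay, within the data shown here, compound 1 and compound 2 stand within the scatter of each other, so compound 3 is the first to show a change at this position, para to a hydroxy group, moving the number beyond the scatter. Dimethylamino in place of iodo gives a number 1.23 log units lower from compound 1 to compound 3 (beyond the scatter), a large step from a single replacement on the shared core. Nothing measured here explains this step. Going by these compounds, whether it depends on the nitrogen or on its two methyl groups remains open. An unsubstituted amine or a methoxy group at the same place would bear on that question.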